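A few compounds are considered here, and "the series" means these few. Any claim that something is new, unique, unknown or untested is made for them only; others in the source may bear on it.

In a functional assay on HEK293 cells for agonist activity at Vasopressin V2 receptor (Homo sapiens), read by a luciferase reporter and cAMP accumulation (on this read-out lower numbers stand for an effect already at smaller amounts and higher numbers for an effect only at larger amounts of compound), compound 1 `Cc1cc(C(=O)N2CCCCc3ccccc32)ccc1CNC(=O)N1C[C@H](O)C[C@H]1C(=O)N(C)C` gives 2.3 nM, compound 2 `CO[C@@H]1C[C@@H](C(=O)N(C)C)N(C(=O)NCc2ccc(C(=O)N3CCCCc4ccccc43)cc2C)C1` gives 4.7 nM, and compound 3 `CCO[C@@H]1C[C@@H](C(=O)N(C)C)N(C(=O)NCc2ccc(C(=O)N3CCCCc4ccccc43)cc2C)C1` gives 4.3 nM. The number for compound 3 lies within the scatter of compound 2 and of compound 1, so none of the three can be set apart from the others. Compound 4 `Cc1cc(C(=O)N2CCCCc3ccccc32)ccc1CNC(=O)N1C[C@H](OC(C)(C)C)C[C@H]1C(=O)N(C)C` differs from compound 3 in one place: tert-butyl in place of ethyl on an oxygen on a saturated carbon. Going by the values given here, the steps that bear on this change all sit on the same oxygen: a 2.0-fold higher number from compound 1 to compound 2 (0.31 log units; beyond the scatter), a 1.9-fold higher number from compound 1 to compound 3 (0.27 log units; within the scatter) and a 1.1-fold lower number from compound 2 to compound 3 (0.04 log units; within the scatter). Capping the hydroxyl with a small alkyl gave at most a modest rise, and adding one more carbon changed nothing beyond the scatter, so a bulkier group here is expected to cost little. Compound 4 is therefore estimated at 6 nM, within 2.5 nM to 15 nM, an expected step of a 1.4-fold higher number from compound 3 to compound 4 (0.14 log units; within the scatter).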

Compound 4, half-maximal effective concentration: 46 nM
Compound 4: the middle estimate sits 7.7-fold (0.88 log units) below what was measured; measured number above the stated range.
By their numbers in this assay, from the lowest: compounds 1, 3 and 2 (each within the scatter of the next, the first and the last beyond it); then compound 4.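

On this oxygen, methyl and ethyl cost little, but tert-butyl does not fit that picture: in place of ethyl it gives an 11-fold higher number from compound 3 to compound 4 (1.03 log units; beyond the scatter) and in place of methyl it gives a 9.8-fold higher number from compound 2 to compound 4 (0.99 log units; beyond the scatter) while in place of hydrogen it gives a 20-fold higher number from compound 1 to compound 4 (1.30 log units; beyond the scatter) overall. So the tolerance seen with the two small groups does not extend to tert-butyl. No measurement at hand explains this jump. From the compounds shown here alone, whether the rise builds gradually or appears only with tert-butyl stays open; isopropyl or a longer chain such as n-butyl on this oxygen would help to show it.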